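This account rests on a few compounds, and the source may have more. Where it says the series, first, only, none or still open, it means among the compounds named here.

Compound 1 `Fc1cc2nc(-c3cncnc3C(F)F)n(C3CC3)c2cc1F`: 18 nM
Compound 2 `Fc1cc2nc(-c3cncnc3C(F)(F)F)n(C3CC3)c2cc1F`: 25 nM
Compound 3 `N#Cc1ccc2nc(-c3cncnc3C(F)F)n(C3CC3)c2n1`: 29 nM

Of the compounds shown here, three have been measured in an assay on cells for inhibition of cytochrome P450 11B2, mitochondrial (Homo sapiens), read by HPLC, with a stated time of 90 min; a higher number here means a weaker inhibitor, a lower number a stronger inhibitor. Compound 1 and compound 2 share one core and differ by a single change, (fluoro in place of hydrogen on a saturated chain carbon bound to an aromatic carbon and two fluorine atoms). That step was a 1.4-fold higher number from compound 1 to compound 2 (0.14 log units; within the scatter), so the two numbers sit together within the usual scatter. Compound 3 is built on a different core; the difference between the core of compound 1 and the core of compound 3 is not broken down here. In this assay compound 3 gives 29 nM, and its number lies within the scatter of both compound 1 and compound 2.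

Compound 4 `N#Cc1ccc2nc(-c3cncnc3C(F)(F)F)n(C3CC3)c2n1` has not yet been measured. It differs from compound 3 by fluoro in place of hydrogen on a saturated chain carbon bound to an aromatic carbon and two fluorine atoms, the same change, in the same place, as that made from compound 1 to compound 2. The step from compound 3 to compound 4 is expected to be a 1.4-fold higher number from compound 3 to compound 4 (0.14 log units; within the scatter), because the earlier step in this assay read a 1.4-fold higher number from compound 1 to compound 2 (0.14 log units; within the scatter). For compound 4 the estimate in this assay is 40 nM, expected to fall between 20 nM and 80 nM.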

Compound 4, half-maximal inhibitory concentration: 24 nM
Estimate against measurement, compound 4: 1.7-fold (0.22 log units) above; the measured number falls inside the stated range.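

In this assay, going from difluoromethyl to trifluoromethyl on the core of compound 3 gave a 1.2-fold lower number from compound 3 to compound 4 (0.08 log units; within the scatter), so on this core, too, the change leaves the number within the scatter. Set beside the same change on the core of compound 1, the two steps cannot be told apart: the same change on two cores in this assay, a 1.4-fold higher number (0.14 log units; within the scatter) from compound 1 to compound 2 and a 1.2-fold lower number (0.08 log units; within the scatter) from compound 3 to compound 4, 1.7-fold (0.22 log units) apart, within the scatter of two such steps. This shows that the change carried from one core to the other without a step beyond the scatter, but it rests on two pairs only, neither step can be told from the scatter of repeated measurements, and it says nothing about any other core.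

The compounds shown carry only difluoromethyl or trifluoromethyl in this place, so it remains open whether a methyl group, a longer chain such as ethyl, or an amine there would read alike on both cores. From the compounds shown here alone, how either pair reads in any other assay also remains open.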